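Swapping the Sulfonyl Substituent in a Pancreatic Cell Growth Inhibitor

The source may report more compounds than this note shows. Statements on the series, on what has been measured and on what is new or still open speak of the compounds shown alone.

Within the data shown here, compound 2 `CC(C)c1noc(N2CCN(C(=O)[C@@H]3CCCN(S(=O)(=O)c4ccc(S(=O)(=O)C(C)C)cc4)C3)CC2)n1` holds the lower of the two numbers so far in a functional assay on MIA PaCa-2 cells (Homo sapiens) for inhibition, read by MTT assay, with a stated time of 7 days (a lower number here means a stronger inhibitor, a higher number a weaker inhibitor), where compound 2 gives 70 nM. Compound 1 `CCOC(=O)[C@@H]1CCCN(S(=N)(=O)c2ccc(S(=O)(=O)N(CC)CC)cc2)C1` gives 12100 nM in this assay. Compound 3 `CCNS(=O)(=O)c1ccc(S(=O)(=O)N2CCC[C@@H](C(=O)N3CCN(c4nc(C(C)C)no4)CC3)C2)cc1` carries ethylamino in place of isopropyl on a sulfonyl sulfur. Among the measured compounds shown here, no step between measured compounds isolates this change, so only a modest shift, if any, beyond the scatter is expected from compound 2 to compound 3 a 2.1-fold higher number from compound 2 to compound 3 (0.33 log units; beyond the scatter). Compound 3 is therefore estimated at 150 nM in this assay, within a range from 40 nM to 600 nM.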

Compound 3, half-maximal inhibitory concentration: 3300 nM
For compound 3 the middle estimate is 22-fold (1.34 log units) below the measured one; measured number outside the range, above it.
By their numbers in this assay, from the lowest: compound 2; then compound 3; then compound 1.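

Putting ethylamino in place of isopropyl on a sulfonyl sulfur gives a 47-fold higher number from compound 2 to compound 3 (1.67 log units; beyond the scatter) in this assay, so this position does not tolerate the change. The two groups have the same count of heavy atoms, yet ethylamino brings a hydrogen-bond donor that isopropyl lacks. No measurement shown here explains the loss. The compounds shown leave open whether the step follows the nitrogen or its hydrogen, which dimethylamino on the same sulfur would help separate. Going by these compounds, how a plain ethyl or a cyclopropyl group would read there also stays open.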